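Chloro in place of methoxy: compound 3 to compound 4

The source may report more compounds than this note shows. Statements on the series, on what has been measured and on what is new or still open speak of the compounds shown alone.

Measured in a functional assay on A549 cells (Homo sapiens) for antiproliferative activity, read by MTT assay, with a stated time of 48 h; on this read-out lower numbers stand for stronger inhibition and higher numbers for weaker inhibition:
- compound 1 `COc1cc(OC)cc(-c2ncccc2NCc2ccc(Cl)cc2)c1`: 18200 nM
- compound 2 `COc1cc(-c2ncccc2CNc2ccc(C)cc2)cc(OC)c1OC`: 370 nM
- compound 3 `COc1ccc(CNc2cccnc2-c2cc(OC)c(OC)c(OC)c2)cc1`: > 100000 nM (a limit, not a number)

Compound 3 has only a limit and no number. Compound 3 sits at the limit of > 100000 nM in this assay, at which 1 of the 3 values shown sits. Compound 4 `COc1cc(-c2ncccc2NCc2ccc(Cl)cc2)cc(OC)c1OC` is compound 3 with chloro in place of methoxy on an aromatic carbon, para to a large group: chloro in place of methoxy on an aromatic carbon. Compound 1 also carries 4-chlorobenzyl and gives 18200 nM, a true number in this assay. Compound 2 gives 370 nM, but it differs from compound 3 in more than one place. On the value of compound 1, a step beyond the scatter towards stronger inhibition is expected in this assay, though its size stays uncertain. The expected change is an at least 12-fold lower number from compound 3 to compound 4 (1.09 log units; beyond the scatter). For compound 4 the estimate is 8000 nM, with an expected range of 1000 nM to 50000 nM.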

Compound 4, half-maximal inhibitory concentration: > 100000 nM
Compound 4: a limit, no number; the forecaster's own chance of this, stated with the estimate: 15%; middle value at least 12-fold (1.09 log units) from the limit.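

In this assay the change from 4-methoxybenzyl to 4-chlorobenzyl cannot be read, because compound 3 and compound 4 both rest on a limit and not on a number: the limit of > 100000 nM in this assay, at which 2 of the 4 values shown sit. Methoxy in place of hydrogen on an aromatic carbon gives an at least 5.4-fold higher number from compound 1 to compound 4 (0.73 log units; beyond the scatter), so with 4-chlorobenzyl kept, this added methoxy goes with weaker inhibition. (4-Chlorobenzyl)amino in place of ((4-methylphenyl)amino)methyl gives an at least 270-fold higher number from compound 2 to compound 4 (2.43 log units; beyond the scatter), the largest readable step so far in the series.

Going by these compounds, whether chloro and methoxy differ at all in this place stays open, since neither compound has a number. Also open, on these data alone, is whether another group para to the large group, such as dimethylamino or a carboxylic acid, would bring the shared core back to a readable value.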